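Chloro for Methoxy on the Benzyl Ring

The source may hold more compounds than are shown below. What is called first, only, known or untested is meant among the compounds shown, and "the series" means these compounds.

Of the compounds shown here, three built on one shared core have been measured in a functional assay on PANC-1 cells (Homo sapiens) for inhibition, read by MTT assay, with a stated time of 72 h; on this read-out lower numbers stand for stronger inhibition of growth and higher numbers for weaker inhibition of growth. Compound 1 `O=S(=O)(NCCCNCc1ccc(C(F)(F)F)cc1)c1cc(C(F)(F)F)cc(C(F)(F)F)c1` gives 3200 nM, compound 2 `O=S(=O)(NCCCNCc1ccc(-c2ccccc2)cc1)c1cc(C(F)(F)F)cc(C(F)(F)F)c1` gives 2500 nM, and compound 3 `COc1ccc(CNCCCNS(=O)(=O)c2cc(C(F)(F)F)cc(C(F)(F)F)c2)cc1` gives 11000 nM, the highest of the three numbers. The steps of a 3.4-fold higher number from compound 1 to compound 3 (0.54 log units; beyond the scatter) and a 4.4-fold higher number from compound 2 to compound 3 (0.64 log units; beyond the scatter) both show that methoxy in this place goes with the higher number. Compound 4 `O=S(=O)(NCCCNCc1ccc(Cl)cc1)c1cc(C(F)(F)F)cc(C(F)(F)F)c1` carries chloro in place of methoxy on an aromatic carbon. Chloro is neither trifluoromethyl nor phenyl, so no measured step matches it exactly, but both steps away from methoxy point the same way. For compound 4 the expected step, resting on a 3.4-fold higher number from compound 1 to compound 3 (0.54 log units; beyond the scatter), is a 2.8-fold lower number from compound 3 to compound 4 (0.44 log units; beyond the scatter). Compound 4 is estimated at 4000 nM, with a range from 1500 nM to 12000 nM.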

Compound 4, concentration for 50% growth inhibition: 4900 nM
Estimate against measurement, compound 4: 1.2-fold (0.09 log units) below, within the range that was stated.
By their numbers in this assay, from the lowest: compounds 2, 1 and 4 (each within the scatter of the next); then compound 3.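

Chloro lifts most of what methoxy costs at this place, with a 2.2-fold lower number from compound 3 to compound 4 (0.35 log units; beyond the scatter) in a step beyond the scatter. Chloro also stays level with the larger groups, with a 2.0-fold higher number from compound 2 to compound 4 (0.29 log units; within the scatter) and a 1.5-fold higher number from compound 1 to compound 4 (0.19 log units; within the scatter) both within the scatter, so among these four compounds only methoxy stands apart from chloro, trifluoromethyl and phenyl. Nothing measured here explains why methoxy stands apart.

On these data alone, whether a hydroxyl or a dimethylamino group at this place would sit with methoxy or with chloro remains open. So does whether chloro keeps its standing on a core with a longer chain.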